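A few compounds are considered here, and "the series" means these few. Any claim that something is new, unique, unknown or untested is made for them only; others in the source may bear on it.

Compound 2 `NS(=O)(=O)NCC1CCN(c2cc(-c3ccccc3Cl)ncn2)CC1` carries a 2-chlorophenyl group on the shared core. In a functional assay on M21 cells (Homo sapiens) for antiproliferative activity, read by sulforhodamine B assay, with a stated time of 48 h (a higher number here means a weaker inhibitor of growth, a lower number a stronger inhibitor of growth), compound 2 gives > 100000 nM, which is a limit of the assay rather than a measured number. Compound 1 `NS(=O)(=O)NCC1CCN(c2cc(-c3ccccc3)ncn2)CC1`, which bears the plain phenyl group, gives > 100000 nM in this assay, again only a limit. Both values sit at the limit of > 100000 nM in this assay, at which 2 of the 2 values shown sit, so the step that the two limits leave unreadable from compound 1 to compound 2 cannot be read. Compound 3 `NS(=O)(=O)NCC1CCN(c2cc(-c3ccccc3F)ncn2)CC1` differs from compound 2 by fluoro in place of chloro on an aromatic carbon. Among the compounds with values here, the only measured step that touches this part of the molecule, a step that the two limits leave unreadable from compound 1 to compound 2, has no readable size, so it gives no direction for the new change. With compound 2 already at the limit, the expected step is a step that the limit leaves unreadable from compound 2 to compound 3, most likely another limit. The estimate for compound 3 in this assay is 150000 nM, with a range from 50000 nM to 1000000 nM.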

Compound 3, concentration for 50% growth inhibition: > 100000 nM
Compound 3 was reported as a limit (the forecaster's own chance of this, stated with the estimate: 85%); the middle value is on the limit's open side.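

In this assay compound 3 gives > 100000 nM, again a limit rather than a number. The steps among compound 1, compound 2 and compound 3 therefore cannot be read: the limit of > 100000 nM in this assay, at which 3 of the 3 values shown sit. These compounds leave open whether the plain phenyl, 2-chlorophenyl and 2-fluorophenyl versions differ at all in growth inhibition.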